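Caco-2 permeability notes: from compound 3 to compound 4

The compounds below may be only part of what the source reports. "The series", "measured", "known", "first", "only" and "open" are said of these compounds alone.

Measured in an ADME assay on Caco-2 cells (Homo sapiens) for permeability, read by LC-MS, with a stated time of 2 h; a higher number here means that the compound crosses the layer faster, a lower number that the compound crosses the layer more slowly:
Compound 1 `COc1cc(CN(CC(C)C)C(CC(=O)O)c2ccc3c(c2)CCO3)ccc1OCCN1C(=O)CCC1=O` gives 0.2 nm/s.
Compound 2 `COc1cc(CN(CC(C)C)C(CC(=O)O)c2ccc(Cl)c(Cl)c2)ccc1OCCN1C(=O)CCC1=O` gives 7 nm/s.
Compound 3 `COc1cc(CN(CC(C)C)C(CC(=O)O)c2ccc(Cl)cc2Cl)ccc1OCCN1C(=O)CCC1=O` gives 28.1 nm/s.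

Compound 3 stands highest of the three; its nearest neighbour is compound 2 at a 4.0-fold higher number from compound 2 to compound 3 (0.60 log units; beyond the scatter), and compound 1 lies furthest at a 140-fold higher number from compound 1 to compound 3 (2.15 log units; beyond the scatter). Compound 4 `COc1cc(CN(CC(C)C)C(CC(=O)O)c2ccc(Cl)c(F)c2)ccc1OCCN1C(=O)CCC1=O` has not been measured. Its change from compound 3 is 4-chloro-3-fluorophenyl in place of 2,4-dichlorophenyl on a saturated chain carbon bound to an amine nitrogen and a saturated chain carbon. The step that bears most directly is a 4.0-fold higher number from compound 2 to compound 3 (0.60 log units; beyond the scatter), since the entering 4-chloro-3-fluorophenyl resembles the 3,4-dichlorophenyl of compound 2 more than the 2,4-dichlorophenyl of compound 3; the steps of a 35-fold higher number from compound 1 to compound 2 (1.54 log units; beyond the scatter) and a 140-fold higher number from compound 1 to compound 3 (2.15 log units; beyond the scatter) show the wider spread of the series. A modest drop in this assay is therefore expected, roughly a 4.7-fold lower number from compound 3 to compound 4 (0.67 log units; beyond the scatter). Compound 4 is estimated at 6 nm/s, within 2 nm/s to 18 nm/s.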

Compound 4, apparent permeability: 5.88 nm/s
Beside the measured number, compound 4's estimate is 1.0-fold (0.01 log units) above it; low and high end bracket the measured number.
By their numbers in this assay, from the lowest: compound 1; then compounds 4 and 2 (each within the scatter of the next); then compound 3.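

With a 1.2-fold lower number from compound 2 to compound 4 (0.08 log units; within the scatter), fluoro in place of chloro on an aromatic carbon leaves compound 4 level with compound 2, so this halogen exchange does not separate the two. The step of a 4.8-fold lower number from compound 3 to compound 4 (0.68 log units; beyond the scatter) shows that 4-chloro-3-fluorophenyl does not reach the 2,4-dichlorophenyl number at this saturated chain carbon, while a 29-fold higher number from compound 1 to compound 4 (1.47 log units; beyond the scatter) keeps it well clear of compound 1. No measurement at hand accounts for these differences.

Open, as far as these compounds go, is how 4-chloro-2-fluorophenyl or unsubstituted phenyl would read at this place, and thus whether the halogen identity or arrangement drives the step from compound 3.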